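The compounds below may be only part of what the source reports. "The series", "measured", "known", "first", "only" and "open" are said of these compounds alone.

Compound 1 `COc1cccc(-c2nc3c(c(C)nn3-c3ccccc3)c(-c3ccccc3O)c2C#N)c1`: > 23000 nM (a limit)
Compound 2 `CCc1ccc(-c2nc3c(c(C)nn3-c3ccccc3)c(-c3ccccc3C#N)c2C#N)cc1`: > 20000 nM (a limit)

In an ADME assay on BJ cells (Homo sapiens) for cytotoxicity, with a stated time of 72 h (a lower number here means that less compound is needed, a higher number that more compound is needed for the effect), compound 2 gives > 20000 nM as a limit and not a number. Compound 3 `CCc1ccc(-c2nc3c(c(C)nn3-c3ccccc3)c(-c3ccccc3F)c2C#N)cc1` differs from compound 2 in one place, with fluoro in place of cyano on an aromatic carbon, ortho to a large group (fluoro in place of cyano on an aromatic carbon). Among the compounds with values here, no measured pair shows such a change, and both measured compounds stand only at limits. In this assay the expected step is (a step that the limit leaves unreadable from compound 2 to compound 3) with no change beyond the scatter. Compound 3 is estimated at 22000 nM with 10000 nM to 45000 nM as its expected range, and the assay may again report only a limit.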

Compound 3, half-maximal effective concentration: > 20000 nM
Compound 3 gave a limit, no number; the forecaster's own chance of this, stated with the estimate: 80%; the middle value lies beyond the limit too.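

Compound 2 and compound 3 both stand only at a limit in this assay, so no step can be read between them: the limit of > 20000 nM in this assay, at which 2 of the 3 values shown sit.

The compounds shown leave open whether fluoro in place of cyano changes the concentration needed for the effect at all.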